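Aryl ether to aryl sulfone at the shared core

The compounds below may be only part of what the source reports. "The series", "measured", "known", "first", "only" and "open" are said of these compounds alone.

Measured compounds:
compound 1 `CC(C)(Oc1ccccc1F)C1OCC(C/C=C\CCC(=O)O)C(c2cccnc2)O1`, 166 nM
compound 2 `COc1ccc(OC(C)(C)C2OCC(C/C=C\CCC(=O)O)C(c3cccnc3)O2)c([N+](=O)[O-])c1`, 6.17 nM

In a functional assay for inhibition, with Homo sapiens as the target (on this read-out higher numbers stand for weaker binding and lower numbers for tighter binding), compound 1 holds the higher of the two numbers; compound 2 sits closest, with a 27-fold lower number from compound 1 to compound 2 (1.43 log units; beyond the scatter). Compound 3 `CC(C)(C1OCC(C/C=C\CCC(=O)O)C(c2cccnc2)O1)S(=O)(=O)c1ccccc1` is not yet measured. It differs from compound 1 by phenylsulfonyl in place of 2-fluorophenoxy on a saturated chain carbon bound to two saturated chain carbons and a saturated ring carbon. Within the data shown here, the one recorded step alters the group at the same place and is large, so this position clearly matters, but no step replaces an aryl ether with a sulfone. For compound 3 the step is expected to be about a 1.8-fold higher number from compound 1 to compound 3 (0.26 log units; within the scatter), with wide uncertainty. Compound 3 is estimated at 300 nM, range 60 nM to 1500 nM.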

Compound 3, dissociation constant: 3160 nM
Compound 3: middle estimate off by 11-fold (1.02 log units), on the low side, and the stated range ends below it.
By their numbers in this assay, from the lowest: compound 2; then compound 1; then compound 3.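

Phenylsulfonyl in place of 2-fluorophenoxy gives a 19-fold higher number from compound 1 to compound 3 (1.28 log units; beyond the scatter) and so moves the number upward at this position, whereas the earlier step of a 27-fold lower number from compound 1 to compound 2 (1.43 log units; beyond the scatter) moved it downward. That earlier step changed only the substituents on the aryl ether, while this one shows that replacing the ether link with a sulfone also carries a large effect. Nothing available accounts for this change. Still open, going by these compounds, is how a phenylthio group or an amine linking the aromatic ring would compare at this saturated chain carbon. Also open, on these data alone, is whether the 4-methoxy-2-nitrophenyl group would lower the number on a sulfone as it does on the ether.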